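This account rests on a few compounds, and the source may have more. Where it says the series, first, only, none or still open, it means among the compounds named here.

Compound 1 `COCCNC(=O)c1cnn(-c2cccc3cc(Cc4cccc(C(F)(F)F)c4)sc23)c1`, compound 2 `O=C(NCCO)c1cnn(-c2cccc3cc(Cc4cccc(C(F)(F)F)c4)sc23)c1` and compound 3 `Cc1nn(-c2cccc3cc(Cc4cccc(C(F)(F)F)c4)sc23)cc1C(=O)NCCO` share a core and were tested in a physicochemical assay for solubility, read by HPLC, at pH 6.8; a higher number here means a more soluble compound, a lower number a less soluble compound. In this assay compound 1 reaches only a limit of < 0.08 ug/mL. Compound 2 likewise gives only a limit, < 0.09 ug/mL. Compound 3 also stops at a limit, < 0.1 ug/mL. Accordingly a step that the two limits leave unreadable from compound 1 to compound 2 and a step that the two limits leave unreadable from compound 2 to compound 3. Compound 4 `COCCNC(=O)c1cnn(-c2cccc3cc(Cc4cccc(C(F)(F)F)c4)sc23)c1C` is still unmeasured; it differs from compound 1 by methyl in place of hydrogen on an aromatic carbon, the same kind of change as from compound 2 to compound 3, (methyl in place of hydrogen on an aromatic carbon), though the surroundings differ: in compound 4 the methyl sits next to the ring atom that bears a large group and carries a (2-methoxyethyl)carbamoyl neighbour, whereas in compound 3 it is two ring bonds from that large group beside a (2-hydroxyethyl)carbamoyl group. The two cores differ by methyl in place of hydrogen on an oxygen on a saturated carbon. Because compound 1 sits at the limit of < 0.08 ug/mL in this assay, at which 1 of the 3 values shown sits, compound 4 is expected to stay near the same floor, a step that the limit leaves unreadable from compound 1 to compound 4. The estimate for compound 4 is 0.05 ug/mL, likely again only a limit.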

Compound 4, solubility: 1.3 ug/mL
Compound 4: the middle estimate sits 26-fold (1.41 log units) below what was measured, outside the stated range (above it).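

In this assay, methyl in place of hydrogen on an aromatic carbon, next to the ring atom that bears a (2-methoxyethyl)carbamoyl group, gives an at least 16-fold higher number from compound 1 to compound 4 (1.21 log units; beyond the scatter) on this core. This is one clear result for one pair of compounds. The same kind of change from compound 2 to compound 3 cannot be read, as both values are limits of the assay, so the data neither show that the gain carries over to another core nor show that it fails to.

Still open, from the compounds shown here alone, is whether an ethyl group or an amine in the same place would match the methyl. Nothing measured here gives a cause for the step.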